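Carboxypiperidine replaces pyrrolidine on the stilbene ether chain

The source may report more compounds than this note shows. Statements on the series, on what has been measured and on what is new or still open speak of the compounds shown alone.

Two stilbene ethers have been measured in a functional assay on the whole organism with Mus musculus as the target, in the maximal electroshock model, at a dose of 50 mg/kg by the oral route; on this read-out lower numbers stand for less inhibition and higher numbers for more inhibition at the one dose given (going by the name of the read-out). Compound 1 `C(=C/c1ccccc1OCCCCN1CCCC1)\c1ccccc1` gives 42.9% in this assay. Compound 2 `CN(C)CCCCOc1ccc(/C=C/c2ccccc2)cc1` gives 12.5% in this assay. Of the two numbers, compound 1 stands highest; compound 2 lies a good way lower, and the gap between the two is beyond the usual scatter. Within the data shown here, no pair differing in a single place has been measured, so no measured step is available for calibration.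

Compound 3 `O=C(O)C1CCCN(CCCCOc2ccccc2/C=C/c2ccccc2)C1` has not yet been measured. Relative to compound 1 the change is 3-carboxypiperidin-1-yl in place of pyrrolidin-1-yl on a saturated chain carbon, four bonds along the chain from an oxygen on an aromatic ring. The basic amine is kept, but a carboxylic acid is added on the ring that carries it, and the ring is enlarged by one carbon.

With no measured step of this kind in hand, the expectation rests only on the value of compound 1 in this assay, 42.9%, and the nature of the change. A decrease is expected, probably beyond the scatter, so that a number 14.9 percentage points lower from compound 1 to compound 3 (beyond the scatter) is estimated as a step down. Compound 3 is estimated at 28%, within a range of 8% to 52%.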

Compound 3, a percentage reported as inhibition, in the whole organism at one dose (the size of the read-out at that dose, not a potency): 12.5%
For compound 3 the middle estimate is 15.5 percentage points above the measured one; the range from low to high includes it.
By their numbers in this assay, from the lowest: compounds 2 and 3 (each within the scatter of the next); then compound 1.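

In this assay, among these compounds, the exchange of pyrrolidin-1-yl for 3-carboxypiperidin-1-yl on a saturated chain carbon, four bonds along the chain from an oxygen on an aromatic ring, gives a number 30.4 percentage points lower from compound 1 to compound 3 (beyond the scatter), a large step and the first single-place step. The read-out at this dose therefore depends strongly on the group at this place on the chain, and keeping a ring amine there does not by itself keep the number of compound 1. The step, however, bundles several changes: the five-membered ring becomes six-membered, the group grows from 5 to 9 heavy atoms, and a carboxylic acid with its hydrogen-bond donor enters.

Still open, on these data alone, is which of these changes carries the step: plain piperidin-1-yl at this place would show the ring enlargement alone, and the ethyl ester of the acid would show the effect of removing the free carboxylic acid. Also open, as far as these compounds go, is whether the location of the acid on the ring matters, which 4-carboxypiperidin-1-yl would test.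

No measurement at hand speaks to the reason for this step.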